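The compounds below may be only part of what the source reports. "The series", "measured", "known", "first", "only" and "open" are said of these compounds alone.

Compound 1 `C/C(=N\NC(=O)/C(C#N)=C/c1ccc(O)cc1)c1c(O)c2ccc(O)cc2oc1=O`: 6020 nM
Compound 2 `COc1cc(/C=C(\C#N)C(=O)N/N=C(\C)c2c(O)c3ccc(O)cc3oc2=O)ccc1O`: 10500 nM
Compound 3 `COc1ccc(/C=C(\C#N)C(=O)N/N=C(\C)c2c(O)c3ccc(O)cc3oc2=O)cc1`: 7850 nM

In a functional assay on HeLa cells (Homo sapiens) for cytotoxicity, read by MTT assay, with a stated time of 24 h (on this read-out higher numbers stand for weaker inhibition and lower numbers for stronger inhibition), compound 3 gives 7850 nM and stands within the scatter of the other two, with a 1.3-fold higher number from compound 1 to compound 3 (0.12 log units; within the scatter) and a 1.3-fold lower number from compound 2 to compound 3 (0.13 log units; within the scatter) as its steps. Compound 4 `C/C(=N\NC(=O)/C(C#N)=C/c1ccc(Br)cc1)c1c(O)c2ccc(O)cc2oc1=O` carries bromo in place of methoxy on an aromatic carbon, para to a large group (bromo in place of methoxy on an aromatic carbon). For the measured compounds named here, no measured compound carries bromo, so the guide is indirect. The two steps that alter this same ring, a 1.3-fold higher number from compound 1 to compound 3 (0.12 log units; within the scatter) and a 1.3-fold lower number from compound 2 to compound 3 (0.13 log units; within the scatter), stayed small, as did a 1.7-fold higher number from compound 1 to compound 2 (0.24 log units; within the scatter) on the same series. No move beyond the scatter is therefore expected, and the estimated step is a 1.2-fold lower number from compound 3 to compound 4 (0.08 log units; within the scatter) in this assay. For compound 4 the estimated value is 6500 nM, with an expected range from 2500 nM to 15000 nM as the likely span.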

Compound 4, half-maximal inhibitory concentration: 10600 nM
Beside the measured number, compound 4's estimate is 1.6-fold (0.21 log units) below it; measured number inside the range.
By their numbers in this assay, from the lowest: compounds 1, 3, 2 and 4 (each within the scatter of the next).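

Bromo in place of methoxy on this aromatic carbon, para to a large group, puts a non-oxygen group here for the first time, yet the number stays within the scatter in this assay (a 1.4-fold higher number from compound 3 to compound 4 (0.13 log units; within the scatter)). The same holds against the hydroxy compound (a 1.8-fold higher number from compound 1 to compound 4 (0.25 log units; within the scatter)) and the 4-hydroxy-3-methoxyphenyl compound (a 1.0-fold higher number from compound 2 to compound 4 (0.00 log units; within the scatter)). Nothing measured here gives a reason for this flat result. On these data alone, whether an amine or a carboxylic acid at this place would move the number beyond the scatter stays open. So do changes elsewhere on the shared core.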